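The compounds below may be only part of what the source reports. "The series", "measured", "known", "first", "only" and "open" are said of these compounds alone.

Among the compounds with values here, in a functional assay on SK-MEL-2 cells (Homo sapiens) for cytotoxicity (a lower number here means a stronger inhibitor, a higher number a weaker inhibitor), only two compounds have numbers so far, and both sit at the weak end of the scale. Compound 1 `Cc1ccc(S(=O)(=O)N2C(=O)NCC2c2ccc(Br)cc2)cc1` gives 80000 nM. Compound 2 `Cc1ccc(C2CNC(=O)N2S(=O)(=O)c2ccc3c(c2)CCC3)cc1` gives 88600 nM, so these two values lie within the usual scatter of each other, and neither can be ranked above the other.

The next compound, compound 3 `O=C1NCC(c2ccc(Br)cc2)N1S(=O)(=O)c1ccc2c(c1)CCC2`, differs from compound 2 in a single place: bromo in place of methyl on an aromatic carbon. This is bromo in place of methyl on an aromatic carbon, which turns 4-methylphenyl into 4-bromophenyl, while the rest of the molecule stays the same.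

Within the data shown here, no measured pair shows this change on its own, so its size cannot be read directly from the data. Among the measured compounds shown here, the only hint comes from compound 1, which also carries the 4-bromophenyl group and gives 80000 nM. On that basis, no step beyond the scatter is expected in this assay, in either direction. The expected change is a 1.1-fold lower number from compound 2 to compound 3 (0.04 log units; within the scatter). The estimate for compound 3 is 80000 nM, with an expected range from 35000 nM to 150000 nM.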

Compound 3, half-maximal inhibitory concentration: 119000 nM
The estimate for compound 3 lay 1.5-fold (0.17 log units) below the measured number; measured number inside the range.
By their numbers in this assay, from the lowest: compounds 1, 2 and 3 (each within the scatter of the next).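

In this assay, within the data shown here, the step of a 1.3-fold higher number from compound 2 to compound 3 (0.13 log units; within the scatter) is the first direct reading of bromo in place of methyl, with the rest of the molecule held the same. At this aromatic carbon, para to a large group, 4-bromophenyl and 4-methylphenyl cannot be told apart in this pair, as the two numbers lie within the normal scatter of repeated measurements. No measured information is available to explain this result.

It remains open whether this position can influence the number at all, since methyl and bromo are the only groups shown there, and an amine, a hydroxyl, a carboxylic acid or a longer chain on the same carbon could give a different result. Going by these compounds, it is also open whether the same swap would look so small in a compound with a much lower number, as all three compounds sit at the weak end of the scale and this single pair cannot establish a general rule.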